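The source may hold more compounds than are shown below. What is called first, only, known or untested is meant among the compounds shown, and "the series" means these compounds.

Compound 3 `CC1(C)CC(NC(=O)C2=NS(=O)(=O)c3cc(Cl)ccc3N2)c2cc([N+](=O)[O-])ccc2O1` sits at the limit of a functional assay on aorta (Rattus norvegicus, strain Wistar) for inhibition (on this read-out higher numbers stand for an effect only at larger amounts of compound and lower numbers for an effect already at smaller amounts), where compound 3 gives > 30000 nM, which is a limit of the assay and not a number. Compound 2 `CC1(C)CC(NC(=O)C2=NS(=O)(=O)c3ccccc3N2)c2cc([N+](=O)[O-])ccc2O1` likewise gives only a limit, > 30000 nM, in this assay. Compound 1 `Cc1ccc2c(c1)S(=O)(=O)N=C(C(=O)NC1CC(C)(C)Oc3ccc(F)cc31)N2` also returns a limit, > 30000 nM, in this assay. The step that the two limits leave unreadable from compound 2 to compound 3 is therefore unreadable, because the limit of > 30000 nM in this assay, at which 3 of the 3 values shown sit, leaves every value shown at the same limit. Compound 4 `Cc1ccc2c(c1)S(=O)(=O)N=C(C(=O)NC1CC(C)(C)Oc3ccc([N+](=O)[O-])cc31)N2` differs from compound 3 by methyl in place of chloro on an aromatic carbon. No readable step bears on this change, so compound 4 is expected to remain near the limit, with an estimated step that the limit leaves unreadable from compound 3 to compound 4. Compound 4 is estimated at 60000 nM, between 20000 nM and 300000 nM.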

Compound 4, half-maximal effective concentration: > 30000 nM
Compound 4: no number, only a limit; the forecaster's own chance of this, stated with the estimate: 85%; the middle value lies beyond the limit too.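

Compound 4 gives > 30000 nM in this assay, which is a limit and not a number. Going by these compounds alone, no step from compound 1, compound 2 or compound 3 to compound 4 can be read, because every value rests on one limit: the limit of > 30000 nM in this assay, at which 4 of the 4 values shown sit. The compounds shown leave open how far any of these changes shifts the read-out in this assay.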